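From 2,6-dimethylphenyl to thiophen-2-yl on a shared core

The compounds below may be only part of what the source reports. "The series", "measured", "known", "first", "only" and "open" are said of these compounds alone.

compound 1 `COC1=C(C)C(=O)/C(=C(O)/C=C/c2ccccc2OC)C(=O)C1(C)C` gives 6.6 ug/mL
compound 2 `COC1=C(C)C(=O)/C(=C(O)/C=C/c2c(C)cccc2C)C(=O)C1(C)C` gives 10.1 ug/mL

In a functional assay on A-431 cells (Homo sapiens) for cytotoxicity (on this read-out higher numbers stand for an effect only at larger amounts of compound and lower numbers for an effect already at smaller amounts), compound 2 cannot be separated from compound 1 (a 1.5-fold higher number from compound 1 to compound 2 (0.18 log units; within the scatter)). Compound 3 (`COC1=C(C)C(=O)/C(=C(O)/C=C/c2cccs2)C(=O)C1(C)C`) remains unmeasured. It carries thiophen-2-yl in place of 2,6-dimethylphenyl on a double-bonded chain carbon bound to a double-bonded chain carbon. Within the data shown here, only one measured step bears on this place, the one between compound 1 and compound 2, and it stayed within the scatter. It is thin evidence, and it involved no five-membered ring. No shift beyond the scatter is therefore expected (a 1.3-fold lower number from compound 2 to compound 3 (0.10 log units; within the scatter)). For compound 3 the estimated value is 8 ug/mL (expected range 3.5 ug/mL to 18 ug/mL).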

Compound 3, concentration for half-maximal effect: 10.8 ug/mL
The estimate for compound 3 lay 1.4-fold (0.13 log units) below the measured number; low and high end bracket the measured number.
By their numbers in this assay, from the lowest: compounds 1, 2 and 3 (each within the scatter of the next).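

In this assay the step to thiophen-2-yl, the first five-membered ring at this place, stays within the scatter, with a 1.1-fold higher number from compound 2 to compound 3 (0.03 log units; within the scatter) and a 1.6-fold higher number from compound 1 to compound 3 (0.21 log units; within the scatter). The place on a double-bonded chain carbon bound to a double-bonded chain carbon has thus carried both six-membered and five-membered aromatic rings, with no step beyond the scatter. No measurement shown here accounts for this result. The compounds shown leave open whether an aromatic ring is needed here at all. They also leave open whether cyclohexyl, or an amine or carboxylic acid on the ring, would shift the number beyond the scatter.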